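Swapping Trifluoromethyl for Chloro on the Benzyl Ring

The source may report more compounds than this note shows. Statements on the series, on what has been measured and on what is new or still open speak of the compounds shown alone.

Compound 1, `O=S(=O)(NCCNCc1cccc2ccccc12)c1cc(C(F)(F)F)cc(C(F)(F)F)c1`, gives 23000 nM in a functional assay on BXPC-3 cells (Homo sapiens) for inhibition, read by MTT assay, with a stated time of 72 h; a higher number here means a weaker inhibitor of growth, a lower number a stronger inhibitor of growth.
Compound 2, `O=S(=O)(NCCCNCc1ccc(C(F)(F)F)cc1)c1cc(C(F)(F)F)cc(C(F)(F)F)c1`, gives 1700 nM in this assay.

Of these two numbers in this assay, compound 2 has the lower one; compound 1 stands well above it, a gap beyond the usual scatter. The next compound, compound 3, `O=S(=O)(NCCCNCc1ccc(Cl)cc1)c1cc(C(F)(F)F)cc(C(F)(F)F)c1`, has not been measured yet. It differs from compound 2 in a single place: chloro in place of trifluoromethyl on an aromatic carbon. Among the compounds with values here, no pair of measured compounds differs in exactly this way, so there is no measured step to lean on. Because compound 2 sits at 1700 nM and everything else in the molecule stays the same, the expectation is a change close to the scatter, if anything a somewhat higher number. The expected step is a 1.5-fold higher number from compound 2 to compound 3 (0.17 log units; within the scatter). The estimate for compound 3 in this assay is 2500 nM, with a range from 800 nM to 8000 nM.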

Compound 3, concentration for 50% growth inhibition: 1600 nM
Estimate against measurement, compound 3: 1.6-fold (0.19 log units) above, and the stated range covers the measured number.
By their numbers in this assay, from the lowest: compounds 3 and 2 (each within the scatter of the next); then compound 1.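

In this assay chloro in place of trifluoromethyl on this aromatic carbon gives a 1.1-fold lower number from compound 2 to compound 3 (0.03 log units; within the scatter) and so leaves the two compounds indistinguishable. Within the data shown here, this is the first step measured at this place on the ring, and it shows that a single chlorine atom can stand where four heavy atoms stood without a difference beyond the scatter, at least for this pair. Nothing measured here explains why the two groups read alike.

On these data alone, it remains open whether this place tolerates any group, since a hydrogen, a methoxy group or a carboxylic acid in the same spot could give a very different reading. As far as these compounds go, compound 1 differs from compound 2 in more than one place, so the effect of a longer chain on its own also remains unknown.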